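The source may report more compounds than this note shows. Statements on the series, on what has been measured and on what is new or still open speak of the compounds shown alone.

The compounds here are compared in a functional assay on the whole organism (strain Sprague-Dawley) for inhibition, with Rattus norvegicus as the target; on this read-out higher numbers stand for an effect only at larger amounts of compound and lower numbers for an effect already at smaller amounts. Compound 1, `COc1ccc2cc(-c3nn[nH]n3)cnc2c1`, gives in this assay only a limit of the assay and no number, > 25 mg/kg; this is the limit of > 25 mg/kg in this assay, at which 1 of the 3 values shown sits. Compound 2, `COc1ccc(OC)c2ncc(C(=O)O)cc12`, likewise gives in this assay only a limit, > 50 mg/kg, which is the limit of > 50 mg/kg in this assay, at which 1 of the 3 values shown sits. For the measured compounds named here, compound 3, `O=C(O)c1cnc2c(Cl)cccc2c1`, is the single compound of the three with a number in this assay, 150 mg/kg. So compound 1 stands at a limit, and of the two further values one is a limit as well. No two of these compounds differ in one place, so no measured step can be read between them.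

Compound 4, `c1ccc2ncc(-c3nn[nH]n3)cc2c1`, has not yet been measured. It differs from compound 1 by hydrogen in place of methoxy on an aromatic carbon. Going by the values given here, no measured pair shows what this change does in this assay, so the direction of the step from compound 1 to compound 4 is open; a step beyond the scatter in either direction is possible, as is none at all. Since compound 1 gives only > 25 mg/kg, the estimate rests on that limit alone. Compound 4 is expected to give about 50 mg/kg in this assay, within 15 mg/kg to 200 mg/kg. That estimate means an expected step that the limit leaves unreadable from compound 1 to compound 4.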

Compound 4, minimum effective dose: 25 mg/kg
Beside the measured number, compound 4's estimate is 2.0-fold (0.30 log units) above it, and the stated range covers the measured number.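

With hydrogen in place of methoxy on this aromatic carbon, this assay gives the first direct reading of a single change among these compounds, and it shows a number no higher from compound 1 to compound 4 (the limit leaves the size open). Compound 4 gives a true number, 25 mg/kg, so on this shared core the methoxy group is not needed for a dose to be read out in the whole animal. The size of the step cannot be read, because compound 1 gives only a limit of the assay and no number: the limit of > 25 mg/kg in this assay, at which 1 of the 4 values shown sits.

The compounds shown therefore leave open whether removing the methoxy group changes the minimum effective dose by a large amount, by a small amount or not at all, since that would take a number for the methoxy compound itself. Going by these compounds, they also show only hydrogen and methoxy at this position on the shared core, so what a different group there, such as an amine or a longer chain like ethoxy, would do to the dose in this assay remains unknown.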